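The compounds below may be only part of what the source reports. "The series", "measured", "known", "first", "only" and "open" are said of these compounds alone.

Compound 1 `O=C(O)Cc1sc(C(c2ccccc2)c2ccccc2)nc1-c1ccccc1`, compound 2 `Cc1nc(-c2ccc(Cl)cc2)c(CC(=O)O)s1` and compound 3 `O=C(O)Cc1sc(C(c2ccc(F)cc2)c2ccc(F)cc2)nc1-c1ccnc(F)c1` have been tested in an in vitro functional assay on HEK285-7 cells for antagonist activity at prostaglandin D2 receptor 2 (Homo sapiens), read by BRET and beta-arrestin recruitment; a higher number here means a weaker inhibitor, a lower number a stronger inhibitor. Compound 1 gives 370 nM, compound 2 gives 41000 nM and compound 3 gives 4.7 nM. Compound 3 stands at the lowest number of the three: its nearest neighbour is compound 1, a gap beyond the scatter, and the furthest is compound 2, a gap far beyond it. Compound 4 `NS(=O)(=O)c1ccc(-c2nc(C(c3ccc(F)cc3)c3ccc(F)cc3)sc2CC(=O)O)cc1` has not yet been measured. It differs from compound 3 in one place: 4-sulfamoylphenyl in place of 2-fluoropyridin-4-yl on an aromatic carbon. Within the data shown here, no measured pair shows such a change, so the expectation rests on compound 3 at 4.7 nM alone. A small upward step is expected, a 1.7-fold higher number from compound 3 to compound 4 (0.23 log units; within the scatter), not beyond the usual scatter. Compound 4 is therefore expected to give about 8 nM in this assay, within a range from 2 nM to 40 nM.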

Compound 4, half-maximal inhibitory concentration: > 100000 nM
Compound 4: no number, only a limit; the forecaster's own chance of this, stated with the estimate: 2%; middle value at least 12000-fold (4.09 log units) away from the limit.
By their numbers in this assay, from the lowest: compound 3; then compound 1; then compound 2. At a limit, above all of these: compound 4.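

Among these compounds, at the aromatic carbon next to the ring nitrogen, the earlier compounds showed only that a strong inhibitor could carry 2-fluoropyridin-4-yl; this change shows that the position does not accept every six-membered aromatic ring. In this assay, 4-sulfamoylphenyl in place of 2-fluoropyridin-4-yl gives an at least 21000-fold higher number from compound 3 to compound 4 (4.32 log units; beyond the scatter), a large step from a single change. Compound 4 stands at a limit of the assay, not at a number: the limit of > 100000 nM in this assay, at which 1 of the 4 values shown sits.

The compounds shown leave open whether the sulfamoyl group or the carbon-only ring accounts for this step. A plain phenyl, or a 4-methylsulfonylphenyl or 4-carbamoylphenyl, at this position would separate the two.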